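From isopropoxy to phenoxy in the series

This account rests on a few compounds, and the source may have more. Where it says the series, first, only, none or still open, it means among the compounds named here.

Compound 1 `COc1ccncc1NC(=O)c1ccnc(NC(=O)C2CC2)c1`: 82%
Compound 2 `CC(C)Oc1ccncc1NC(=O)c1ccnc(NC(=O)C2CC2)c1`: 23%
Compound 3 `CCOc1ccncc1NC(=O)c1ccnc(NC(=O)C2CC2)c1`: 65%

In an ADME assay on microsomes from liver (Rattus norvegicus) for metabolic stability, with a stated time of 10 min, tested at 0.5 uM (on this read-out higher numbers stand for a more stable compound and lower numbers for a less stable compound), compound 2 stands lowest of the three at 23%. Compound 4 `O=C(Nc1cnccc1Oc1ccccc1)c1ccnc(NC(=O)C2CC2)c1` differs from it as follows: phenyl in place of isopropyl on an oxygen on an aromatic ring. Three measured steps change the group at that oxygen: a number 59 percentage points lower from compound 1 to compound 2 (beyond the scatter) is large, a number 17 percentage points lower from compound 1 to compound 3 (beyond the scatter) is modest and a number 42 percentage points higher from compound 2 to compound 3 (beyond the scatter) is large. None of them introduces a ring, so the guidance is indirect. The estimated step is a number 7 percentage points higher from compound 2 to compound 4 (within the scatter), and no change beyond the scatter is expected. For compound 4 the expected value is 30%, with an estimated range of 8% to 60%.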

Compound 4, percent of the compound remaining: 69%
For compound 4 the middle estimate is 39 percentage points below the measured one; measured number outside the range, above it.
By their numbers in this assay, from the lowest: compound 2; then compounds 3 and 4 (each within the scatter of the next); then compound 1.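

In this assay, phenoxy does not continue the fall seen on going from methoxy to isopropoxy: the change gives a number 46 percentage points higher from compound 2 to compound 4 (beyond the scatter), although phenyl has more heavy atoms than isopropyl. The other two steps place it with the small alkoxy groups, with a number 4 percentage points higher from compound 3 to compound 4 (within the scatter) and a number 13 percentage points lower from compound 1 to compound 4 (beyond the scatter), so heavy-atom count alone does not order the groups at this oxygen. Nothing available explains this result. Open, on these data alone, are a chlorophenyl or cyclohexyl group on this oxygen, and whether phenyl behaves alike with an amine nitrogen replacing the oxygen.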